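The compounds below may be only part of what the source reports. "The series", "measured", "known", "first", "only" and "open" are said of these compounds alone.

Working notes on the series.

Compound 1 `Cc1cc(C(=O)O)nn1C(C)c1cc(Cl)ccc1OCc1ccccc1` gives 10 nM in an assay on CHO-K1 cells for displacement of a labelled ligand from prostaglandin E2 receptor EP1 subtype (Homo sapiens); a lower number here means a stronger inhibitor, a higher number a weaker inhibitor. Compound 2 `CNC(=O)c1cc(C)n(Cc2cc(Cl)ccc2OCc2ccccc2)n1` gives 100 nM in this assay. For the measured compounds named here, compound 3 `Cc1cc(C(=O)Nc2ccccc2)nn1Cc1cc(Cl)ccc1OCc1ccccc1` gives 39.8 nM in this assay, which places it second of the three numbers measured so far: compound 2 stands at a higher number, compound 1 at a lower one. Going by the values given here, the one step measured within a single change is a 2.5-fold lower number from compound 2 to compound 3 (0.40 log units; beyond the scatter).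

Compound 4 `Cc1cc(C(=O)Nc2c(F)cccc2F)nn1Cc1cc(Cl)ccc1OCc1ccccc1` is not yet measured. It differs from compound 3 by 2,6-difluorophenyl in place of phenyl on an amide-type nitrogen. Among the compounds with values here, no measured step bears on the exchange of phenyl for 2,6-difluorophenyl on an amide-type nitrogen; the only measured step on that nitrogen, a 2.5-fold lower number from compound 2 to compound 3 (0.40 log units; beyond the scatter), concerns methyl against phenyl and so is of another kind. The expectation for compound 4 therefore rests on compound 3 alone, with no shift beyond the scatter assumed; the expected step is a 1.2-fold lower number from compound 3 to compound 4 (0.09 log units; within the scatter). Compound 4 is estimated at 32 nM in this assay, with a range from 10 nM to 100 nM.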

Compound 4, half-maximal inhibitory concentration: 10 nM
For compound 4 the middle estimate is 3.2-fold (0.51 log units) above the measured one; low and high end bracket the measured number.
By their numbers in this assay, from the lowest: compounds 1 and 4 (each within the scatter of the next); then compound 3; then compound 2.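

On the amide-type nitrogen, the substitution of the aryl group matters as well as its presence: in this assay, 2,6-difluorophenyl in place of phenyl gives a 4.0-fold lower number from compound 3 to compound 4 (0.60 log units; beyond the scatter) and so extends the gain first seen with phenyl in place of methyl. Across the three amides, which differ only in this group, the numbers fall in the order methyl, phenyl, 2,6-difluorophenyl, with none going against that order, and the whole span is a 10-fold lower number from compound 2 to compound 4 (1.00 log units; beyond the scatter). No measurement at hand accounts for the effect of the two fluorines.

Whether both fluorines are needed remains open, as a single fluoro group on the phenyl is not among the compounds shown. Also open, as far as these compounds go, is how chloro or methoxy groups on that phenyl, or a pyridyl or cyclohexyl group in its place, would compare on this nitrogen.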